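Methoxy for nitro on the triazole benzyl arm

The compounds below may be only part of what the source reports. "The series", "measured", "known", "first", "only" and "open" are said of these compounds alone.

Measured so far:
compound 1 `O=c1ccoc2cc(OCc3cn(Cc4ccc(Cl)cc4)nn3)ccc12` — > 100000 nM
compound 2 `O=c1ccoc2cc(OCc3cn(Cc4ccc([N+](=O)[O-])cc4)nn3)ccc12` — > 100000 nM

In a functional assay on SGC-7901 cells (Homo sapiens) for cytotoxicity, read by MTT assay, with a stated time of 48 h (on this read-out lower numbers stand for stronger inhibition and higher numbers for weaker inhibition), compound 1 reaches only the limit of the assay, reported as > 100000 nM. Compound 2 likewise gives no number in this assay, only the limit > 100000 nM. The one measured step, a step that the two limits leave unreadable from compound 1 to compound 2, is therefore unreadable in size, as shown by the limit of > 100000 nM in this assay, at which 2 of the 2 values shown sit, where both values sit at the same limit. Compound 2 stands, on the numbers shown, at that limit and nowhere more precise.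

Compound 3 `COc1ccc(Cn2cc(COc3ccc4c(=O)ccoc4c3)nn2)cc1` differs from compound 2 by methoxy in place of nitro on an aromatic carbon. Within the data shown here, no measured step bears directly on this change, since the only step known ends at the limit on both sides. From the two compounds that define this series, both sitting at the limit, the expected step is a number no higher from compound 2 to compound 3 (the limit leaves the size open). The estimate for compound 3 is accordingly 100000 nM, between 30000 nM and 300000 nM, with a strong chance that this assay again reports only a limit.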

Compound 3, half-maximal inhibitory concentration: > 100000 nM
Compound 3 gave a limit, no number; the forecaster's own chance of this, stated with the estimate: 75%; the middle value sits exactly at the limit.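

No step can be read among compound 1, compound 2 and compound 3, since each result in this assay is a limit and not a number: the limit of > 100000 nM in this assay, at which 3 of the 3 values shown sit.

The compounds shown leave open how chloro, nitro and methoxy compare, and whether any change to the shared core would give a readable number.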